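The source may report more compounds than this note shows. Statements on the series, on what has been measured and on what is new or still open speak of the compounds shown alone.

Compound 1 `COc1cc(/C=C/c2ccc3ccccc3c2)cc([N+](=O)[O-])c1OC`: > 10000 nM (a limit)
Compound 2 `COc1cc(/C=C\c2ccc3ccccc3c2)cc([N+](=O)[O-])c1OC`: 420 nM

Within the data shown here, in a functional assay on HT-29 cells (Homo sapiens) for inhibition (a lower number here means a stronger inhibitor, a higher number a weaker inhibitor), compound 2 gives 420 nM, the only true number so far. Compound 1 gives > 10000 nM, which is a limit of the assay and not a number. This limit is described by the limit of > 10000 nM in this assay, at which 1 of the 2 values shown sits.

The next compound is compound 3 `COc1c([N+](=O)[O-])cc(/C=C\c2ccc3ccccc3c2)cc1[N+](=O)[O-]`, which keeps the double bond drawn Z, as in compound 2. The change is nitro in place of methoxy on an aromatic carbon, ortho to a methoxy group, meta to a large group and meta to a nitro group.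

Just one measured step bears on this, an at least 23-fold lower number from compound 1 to compound 2 (1.37 log units; beyond the scatter), and it is large. It reflects (the fact that compounds 1 and 2 differ only in the configuration as drawn), so it says nothing directly about swapping one group for another. It shows only that this small set can respond strongly to a single change. With so little to go on, a moderate move towards a higher number, beyond the scatter, seems the most reasonable expectation. That would mean a weaker inhibitor.

The estimated change is a 4.3-fold higher number from compound 2 to compound 3 (0.63 log units; beyond the scatter). For compound 3 the expected value is 1800 nM, with an estimated range from 350 nM to 10000 nM.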

Compound 3, half-maximal inhibitory concentration: > 5000 nM
Compound 3: only a limit was reported; the forecaster's own chance of this, stated with the estimate: 15%; middle value at least 2.7-fold (0.44 log units) from the limit.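

In this assay, replacing methoxy with nitro at this place, ortho to a methoxy group and meta to a nitro group, is far from a neutral swap: the result is an at least 11-fold higher number from compound 2 to compound 3 (1.07 log units; beyond the scatter), a large step in the weaker direction. Compound 3 gives > 5000 nM, which is a limit of the assay and not a number, and the full size of the step therefore cannot be read. Among these compounds, until now the only large step came from the configuration of the double bond, whereas here the double bond is drawn Z in both compounds, and this shows that a single group on the aromatic ring can also make a large difference.

The compounds shown do not reveal whether the loss comes from the loss of methoxy or from the arrival of nitro, and one replacement at one place cannot separate the two. An amine at this same carbon, or a longer ethoxy chain in place of methoxy, would be a natural further comparison with compound 2.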